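The source may report more compounds than this note shows. Statements on the series, on what has been measured and on what is new or still open speak of the compounds shown alone.

Measured so far in a functional assay on HT-29 cells (Homo sapiens) for antiproliferative activity, read by sulforhodamine B assay, with a stated time of 48 h; on this read-out lower numbers stand for stronger inhibition and higher numbers for weaker inhibition:
compound 1 `CCCC(=O)Nc1ccc(S(=O)(=O)Oc2ccccc2C(C)C)cc1`, 4900 nM
compound 2 `CCCC(=O)Nc1ccc(S(=O)(=O)Oc2ccccc2I)cc1`, 11000 nM
compound 3 `O=C(CCCl)Nc1ccc(S(=O)(=O)Oc2ccccc2I)cc1`, 14000 nM

Compound 1 gives the lowest number of the three; compound 2 sits at a 2.2-fold higher number from compound 1 to compound 2 (0.35 log units; beyond the scatter), and compound 3 further out, so compound 1 is the reference point with the strongest inhibition in this set. The step between compound 2 and compound 3 is a 1.3-fold higher number from compound 2 to compound 3 (0.10 log units; within the scatter).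

Compound 4 `CCCCCNC(=O)Nc1ccc(S(=O)(=O)Oc2ccccc2C(C)C)cc1` is not yet measured. It differs from compound 1 by pentylamino in place of propyl on a carbonyl carbon. Neither measured step covers this change: the step from compound 1 to compound 2 concerns the aromatic substituent, and the step from compound 2 to compound 3 concerns the chain carbon on the acyl side, where a change stayed within the scatter. Among the compounds with values here, no measured pair shows what replacing the propyl on the carbonyl carbon with pentylamino does. The expectation therefore rests on compound 1 alone, with a wide range and no clear direction; a step of a 1.0-fold higher number from compound 1 to compound 4 (0.01 log units; within the scatter) is expected, which is within the scatter. Compound 4 is estimated at 5000 nM, with a range from 1500 nM to 16000 nM.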

Compound 4, half-maximal inhibitory concentration: 4900 nM
For compound 4 the middle estimate is 1.0-fold (0.01 log units) above the measured one, and the stated range covers the measured number.
By their numbers in this assay, from the lowest: compounds 1 and 4 (each within the scatter of the next); then compounds 2 and 3 (each within the scatter of the next).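

In this assay, pentylamino in place of propyl on the carbonyl carbon gives no change at the digits printed from compound 1 to compound 4 (within the scatter). Within the data shown here, this is the first change at this position: compounds 1, 2 and 3 vary only the aromatic substituent and a saturated chain carbon on the acyl side, and so say nothing about the group on the carbonyl carbon itself. Here the (propylcarbonyl)amino to (pentylcarbamoyl)amino change adds a longer chain, a nitrogen and a hydrogen-bond donor while the number stays in place, so this position accepts that exchange in the present core, and nothing on hand explains why the number holds.

Still open, going by these compounds, is whether the same holds on this carbonyl carbon for a shorter ethylamino, a ring such as cyclohexylamino, or a chain ending in a carboxylic acid. Also open, on these data alone, is whether pentylamino gives the same picture with iodo rather than isopropyl on the aromatic carbon, as in the core of compound 2.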